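Chlorine for fluorine on a thioether-linked phenyl ring

The source may report more compounds than this note shows. Statements on the series, on what has been measured and on what is new or still open speak of the compounds shown alone.

Of the compounds shown here, three sharing one core have been measured in a functional assay on A549 cells (Homo sapiens) for inhibition, read by sulforhodamine B assay, with a stated time of 48 h; on this read-out lower numbers stand for stronger inhibition of growth and higher numbers for weaker inhibition of growth. Compound 1 `CCOC(=O)[C@H](CCC(=O)O)NC(=O)c1ccc(Sc2nc3cc(N)cc(N)c3nc2-c2ccccc2)cc1` gives 20400 nM, compound 2 `Nc1cc(N)c2nc(-c3ccccc3)c(Sc3ccc(F)cc3)nc2c1` gives 13500 nM, and compound 3 `COc1cc(CNc2nc3cc(N)cc(N)c3nc2-c2ccccc2)cc(OC)c1OC` gives 4270 nM. Among these three numbers compound 2 stands second highest. Its nearest neighbour is compound 1, whose number is within the usual scatter of that of compound 2, so nothing can be said about which of the two is the stronger inhibitor of growth. Its furthest neighbour is compound 3, whose lower number lies beyond the scatter, so compound 3 inhibits growth more strongly than compound 2.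

Compound 4 `Nc1cc(N)c2nc(-c3ccccc3)c(Sc3ccc(Cl)c(Cl)c3)nc2c1` has not yet been measured. It differs from compound 2 in one place: 3,4-dichlorophenyl in place of 4-fluorophenyl on a sulfur. For the measured compounds named here, no pair of measured compounds shows what such a change does here, so any expectation rests on the general observation that compounds 1, 2 and 3 all fall within a fairly narrow band. A step of modest size is expected, a 1.5-fold lower number from compound 2 to compound 4 (0.18 log units; within the scatter), with a slight lean toward a lower number but not clearly beyond the scatter. For compound 4 in this assay a value near 9000 nM is estimated, within a range from 3000 nM to 30000 nM.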

Compound 4, concentration for 50% growth inhibition: 13500 nM
The estimate for compound 4 lay 1.5-fold (0.18 log units) below the measured number, within the range that was stated.
By their numbers in this assay, from the lowest: compound 3; then compounds 2, 4 and 1 (each within the scatter of the next).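

In this assay, putting 3,4-dichlorophenyl in place of 4-fluorophenyl on a sulfur gives no change at the digits printed from compound 2 to compound 4 (within the scatter). For the compounds shown here, this is the first direct comparison at this position, and it shows that these two substituted phenyl rings cannot be told apart in inhibition of growth, even though the entering group has a different halogen pattern and one more heavy atom. No other data accompany this pair, so the result offers no explanation for why the two compounds cannot be separated.

As far as these compounds go, one pair cannot show whether the whole position tolerates change or whether these two rings simply happen to match, so a plain phenyl ring, a phenyl ring bearing a hydroxyl group or a nitrile, and a hexyl chain on the sulfur in place of the ring all remain open tests. Any of these, set on the shared core in the same place, would show whether the group on the sulfur can alter the number at all.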